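The compounds below may be only part of what the source reports. "The series", "measured", "known", "first", "only" and "open" are said of these compounds alone.

Compound 1, with the structure `Nc1ccnc(-c2nn(Cc3ccccc3F)c3ncccc23)n1`, has been measured more than once in a functional assay (aorta) with Oryctolagus cuniculus as the target; on this read-out higher numbers stand for weaker inhibition and lower numbers for stronger inhibition; compound 1 gives 270 nM; 265000 nM (2 entries) there, and the spread between those entries is far beyond the usual scatter, as the several entries of compound 1 show (the several entries of compound 1 in this assay, 270 nM; 265000 nM (2 entries)). Compound 2, `Cc1cnc(-c2nn(Cc3ccccc3F)c3ncccc23)nc1N`, is weaker on the only number shown for it: in this assay compound 2 gives 675000 nM, and one further entry for compound 2 carries no single number. Compound 3, `CCc1cnc(-c2nn(Cc3ccccc3F)c3ncccc23)nc1N`, has not yet been measured. It differs from compound 2 by methyl in place of hydrogen on a saturated chain carbon bound to an aromatic carbon, which, cut one bond further out, reads methyl to ethyl. No measured step of this kind exists among these compounds, so the expected step from compound 2 to compound 3 is a 1.1-fold lower number from compound 2 to compound 3 (0.05 log units; within the scatter), with no direction beyond the scatter. For compound 3 a value of 600000 nM is expected, within a range from 150000 nM to 2500000 nM.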

Compound 3, half-maximal inhibitory concentration: 272000 nM
Estimate against measurement, compound 3: 2.2-fold (0.34 log units) above, within the range that was stated.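

Methyl to ethyl, on a saturated chain carbon bound to an aromatic carbon, now has a measured step in this assay: a 2.5-fold lower number from compound 2 to compound 3 (0.39 log units; beyond the scatter). Among the compounds shown here, this is the first sign that the position takes the larger chain without a loss, and the change moves the number towards stronger inhibition by a modest amount that lies beyond the scatter. How far so small a step can be trusted remains uncertain, because repeated entries for a single compound in this assay disagree by far more than the step itself: the several entries of compound 1 in this assay, 270 nM; 265000 nM (2 entries).

Going by these compounds, whether a propyl chain or a longer chain at this place would continue the direction stays open, as does the outcome with a branched isopropyl group. The compounds shown also leave open what a hydroxymethyl group or an amine would do at this place.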